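The source may hold more compounds than are shown below. What is called first, only, known or untested is meant among the compounds shown, and "the series" means these compounds.

Compound 1 `COc1ccc(/C(C)=C(/C)C(=O)NC2CC2)cc1` gives 300 mg/kg in a toxicity assay on the whole organism (strain Icem-CET (SPF Caw)) for cytotoxicity, with Mus musculus as the target; on this read-out lower numbers stand for an effect already at smaller amounts and higher numbers for an effect only at larger amounts of compound.
Compound 2 `COc1ccc(/C(C)=C(\C)C(=O)NC2CC2)cc1` gives 250 mg/kg in this assay.
Compound 3 `C=CCNC(=O)/C(C)=C(\C)c1cc(OC)c(OC)c(OC)c1` gives 110 mg/kg in this assay.

Among these three numbers compound 2 stands second highest; compound 1 lies nearest, with a 1.2-fold lower number from compound 1 to compound 2 (0.08 log units; within the scatter), and compound 3 lies furthest, at 110 mg/kg. Compound 4 `C/C(C(=O)NC1CC1)=C(/C)c1ccccc1` keeps the core of compound 2 and differs by hydrogen in place of methoxy on an aromatic carbon. Going by the values given here, the only measured step, a 1.2-fold lower number from compound 1 to compound 2 (0.08 log units; within the scatter), concerns a change in configuration alone and does not bear on the loss of a methoxy group; no measured pair shows what that loss does in this assay. A step within the scatter is therefore expected, no change at the digits printed from compound 2 to compound 4 (within the scatter). Compound 4 is estimated to give 250 mg/kg, with a range from 120 mg/kg to 500 mg/kg.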

Compound 4, dose for half-maximal effect: 100 mg/kg
Beside the measured number, compound 4's estimate is 2.5-fold (0.40 log units) above it; the measured number lies below the stated range.
By their numbers in this assay, from the lowest: compounds 4 and 3 (each within the scatter of the next); then compounds 2 and 1 (each within the scatter of the next).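

In this assay, hydrogen in place of methoxy on the aromatic carbon para to a large group gives a 2.5-fold lower number from compound 2 to compound 4 (0.40 log units; beyond the scatter), so this change, unlike the change in configuration alone, moves the number beyond the scatter. On this core, the effect therefore appears at smaller amounts without the methoxy group. Nothing shown here bears on why the number falls. From the compounds shown here alone, whether an amine, a fluorine atom or an ethoxy group at this position would lower or raise the number stays open. Going by these compounds, it is also open whether the same step holds for the double-bond configuration of compound 1.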